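Moving the bromine on the benzyl group of compound 1

A few compounds are considered here, and "the series" means these few. Any claim that something is new, unique, unknown or untested is made for them only; others in the source may bear on it.

Compound 1 `COc1ccc(S(=O)(=O)N(Cc2cccc(Br)c2)[C@H](C)C(=O)NO)cc1` is a hydroxamic acid carrying a bromobenzyl group on its sulfonamide nitrogen. Among the measured compounds shown here, in an assay on isolated protein for inhibition of bone morphogenetic protein 1 (Homo sapiens) (on this read-out lower numbers stand for stronger inhibition and higher numbers for weaker inhibition), compound 1 gives 93 nM, the highest of the three numbers measured so far. Compound 2 `COc1ccc(S(=O)(=O)N(Cc2cccc3ccccc23)[C@H](C)C(=O)NO)cc1` gives 90 nM in this assay, which sits within the scatter of the number for compound 1. Compound 3 `COc1ccc(S(=O)(=O)N(Cc2sccc2Oc2ccccc2)[C@H](C)C(=O)NO)cc1` gives 40 nM in this assay, a lower number than compound 1 by a margin beyond the scatter.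

Compound 4 `COc1ccc(S(=O)(=O)N(Cc2ccc(Br)cc2)[C@H](C)C(=O)NO)cc1` has not yet been measured. It differs from compound 1 in one place: 4-bromophenyl in place of 3-bromophenyl on a saturated chain carbon bound to a sulfonamide nitrogen. The two compounds share the same atoms, joined differently. For the measured compounds named here, no measured pair shows what this rearrangement does here, so the expected step is a 1.1-fold higher number from compound 1 to compound 4 (0.03 log units; within the scatter), small and in no direction beyond the scatter. In this assay compound 4 is estimated at 100 nM, with a range from 40 nM to 250 nM.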

Compound 4, half-maximal inhibitory concentration: 37 nM
Compound 4: the middle estimate sits 2.7-fold (0.43 log units) above what was measured; the whole stated range lies above it.
By their numbers in this assay, from the lowest: compounds 4 and 3 (each within the scatter of the next); then compounds 2 and 1 (each within the scatter of the next).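

Among the compounds shown here, compounds 1 and 4 form the first measured pair that differs in only one place, so they give the first direct reading of this position. Going from 3-bromophenyl to 4-bromophenyl keeps the same atoms yet gives a 2.5-fold lower number from compound 1 to compound 4 (0.40 log units; beyond the scatter) in this assay and shows that the place of the bromine on this ring counts, even though the group's composition stays unchanged. Nothing in the data shown accounts for this step.

The compounds shown leave open whether this difference belongs to bromine alone, since a single pair cannot show whether another group would respond in the same way. Pairs carrying a chlorine or a methyl group in place of the bromine, at each of the same two ring places, would address that question.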